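A few compounds are considered here, and "the series" means these few. Any claim that something is new, unique, unknown or untested is made for them only; others in the source may bear on it.

Measured compounds:
compound 1, `CC(C)CCCN(C(=O)[C@@H]1C[C@H]1c1ccccc1)c1ccc(-c2ccccc2)cc1`, in a functional assay for agonist activity at G protein-coupled receptor 88 (Homo sapiens), read by HTRF and cAMP accumulation (on this read-out lower numbers stand for an effect already at smaller amounts and higher numbers for an effect only at larger amounts of compound), gives a limit, > 100 nM.
compound 2, `N[C@H](CN(C(=O)[C@@H]1C[C@H]1c1ccccc1)c1ccc(-c2ccccc2)cc1)C1CCCCC1`, in this assay gives 0.66 nM.

Among the measured compounds shown here, compound 2 holds the only numeric value shown; the other entry is a limit (the limit of > 100 nM in this assay, at which 1 of the 2 values shown sits). For the measured compounds named here, the single measured step, an at least 150-fold lower number from compound 1 to compound 2 (2.18 log units; beyond the scatter), put an amine and a cyclohexyl ring in place of a plain branched chain, with a large gain. Compound 3, `CC(C)(C)[C@H](N)CN(C(=O)[C@@H]1C[C@H]1c1ccccc1)c1ccc(-c2ccccc2)cc1`, keeps that amine and changes only the ring: tert-butyl in place of cyclohexyl on a saturated chain carbon bound to an amine nitrogen and a saturated chain carbon. The step from compound 1 to compound 2 does not separate the share of the amine from that of the ring, so it speaks only weakly to this exchange of one saturated carbon group for another. The step of a 2.3-fold higher number from compound 2 to compound 3 (0.36 log units; beyond the scatter) is therefore expected to be small, at most a modest loss. For compound 3 the expected value in this assay is 1.5 nM, within 0.4 nM to 6 nM.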

Compound 3, half-maximal effective concentration: 11 nM
The estimate for compound 3 lay 7.3-fold (0.87 log units) below the measured number; measured number above the stated range.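

In this assay, the exchange of cyclohexyl for tert-butyl on this chain carbon brings a 17-fold higher number from compound 2 to compound 3 (1.22 log units; beyond the scatter) and so counts as a large loss, which means these two saturated carbon groups are not interchangeable here. With tert-butyl in the group, the amine-bearing chain still gives an at least 9.0-fold lower number from compound 1 to compound 3 (0.95 log units; beyond the scatter) and so keeps a clear gain over isopentyl, which means the gain does not depend on cyclohexyl alone. That step is only a bound, as the number for compound 1 is a limit: the limit of > 100 nM in this assay, at which 1 of the 3 values shown sits.

From the compounds shown here alone, it remains open how a phenyl or cyclopentyl ring, or a smaller isopropyl group, would fare at this place. Also open, going by these compounds, is what cyclohexyl would give with a hydroxyl group in place of the amine, which would help separate the share of the amine from that of the ring.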